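A few compounds are considered here, and "the series" means these few. Any claim that something is new, unique, unknown or untested is made for them only; others in the source may bear on it.

Measured so far:
compound 1 `O=C(O)Cc1sc(C(c2ccc(F)cc2)c2ccc(F)cc2)nc1-c1ccnc(N2CCCC2)c1` gives 80%
compound 2 `O=C(O)Cc1sc(NC(=O)c2ccccc2)nc1-c1ccc(Cl)cc1` gives 50%

Both numbers come from an in vitro functional assay on HEK285-7 cells for antagonist activity at prostaglandin D2 receptor 2 (Homo sapiens), read by BRET and beta-arrestin recruitment; a higher number here means a larger maximal response, a lower number a smaller maximal response. Of the two values in hand, compound 1 holds the higher one; the value of compound 2 sits lower, and the gap between the two lies beyond the usual scatter of this assay. No other comparison is available, and nothing has yet been measured that changes compound 1 in a single place.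

The next compound in the series, compound 3 `Cc1cc(-c2nc(C(c3ccc(F)cc3)c3ccc(F)cc3)sc2CC(=O)O)ccn1`, does exactly that. Relative to compound 1 the change is methyl in place of pyrrolidin-1-yl on an aromatic carbon. In terms of the larger group carried by the shared core, this reads as 2-(pyrrolidin-1-yl)pyridin-4-yl becoming 2-methylpyridin-4-yl, while the diarylmethyl part and the acetic acid side chain of the core are kept.

Among the compounds with values here, with no measured pair of this kind to lean on, the expected step in this assay from compound 1 to compound 3 is a small one, a number 10 percentage points lower from compound 1 to compound 3 (within the scatter), most likely downward but possibly no larger than the scatter. For compound 3 the estimated maximal response is therefore 70%, with a range from 50% to 90%.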

Compound 3, largest response reached (reported as efficacy), in percent of the reference or control that the assay uses: 80%
Compound 3: middle estimate off by 10 percentage points, on the low side; the range from low to high includes it.
By their numbers in this assay, from the lowest: compound 2; then compounds 1 and 3 (each within the scatter of the next).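

In this assay, within the data shown here, methyl in place of pyrrolidin-1-yl on the aromatic carbon next to the ring nitrogen gives no change at the digits printed from compound 1 to compound 3 (within the scatter), which is the first comparison that changes a single place. For this pair, with the diarylmethyl part and the acetic acid side chain kept, the maximal response does not require the five-membered non-aromatic ring or its nitrogen: a single methyl carbon with no ring and no hydrogen-bond acceptor reads the same within the scatter. No supporting data bear on why these two groups read alike.

Among these compounds, only two groups at this position appear here, so it remains open whether a plain hydrogen, a small open-chain amine such as dimethylamino, a methoxy group, a longer chain such as n-butyl or a carboxylic acid would also leave the response in this assay in the same place. Also open, as far as these compounds go, is whether the same holds when the diarylmethyl part is replaced by another group, as this single pair carries that part on both sides.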